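Chlorothiophene in place of chlorophenyl on the ether side

The source may hold more compounds than are shown below. What is called first, only, known or untested is meant among the compounds shown, and "the series" means these compounds.

Compound 1 `Cn1c(C2CC2)nc2ccc(-n3ccc(OCc4ccc(Cl)cc4)cc3=O)cc21`: 21 nM
Compound 2 `Cn1c(C2CCC2)nc2ccc(-n3ccc(OCc4ccc(F)cc4)cc3=O)cc21`: 210 nM
Compound 3 `Cn1c(CC(C)(C)C)nc2ccc(-n3ccc(OCc4ccc(F)cc4)cc3=O)cc21`: > 1000 nM

All numbers come from an assay on CHO cells for displacement of a labelled ligand from melanin-concentrating hormone receptor 1 (Rattus norvegicus), read by scintillation counting, with a stated time of 1 h; on this read-out higher numbers stand for weaker inhibition and lower numbers for stronger inhibition. Among the measured compounds shown here, compound 1 gives the lowest of the two numbers; compound 2 sits at a higher number, but the two differ both in the group on the aromatic carbon of the core and in the halogen on the benzyl ring, so the pair yields no single step. Compound 3 reaches only a limit of this assay, (the limit of > 1000 nM in this assay, at which 1 of the 3 values shown sits). For the measured compounds named here, the one step that changes a single place, an at least 4.7-fold higher number from compound 2 to compound 3 (0.67 log units; beyond the scatter), concerns the group on the aromatic carbon of the core and not the benzyloxy side.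

Compound 4 `Cn1c(C2CC2)nc2ccc(-n3ccc(OCc4ccc(Cl)s4)cc3=O)cc21` shares the core of compound 1 and alters the oxygen-linked group: 5-chlorothiophen-2-yl in place of 4-chlorophenyl on a saturated chain carbon bound to an oxygen on an aromatic ring. Going by the values given here, no measured step touches this position, and the halogen difference between compound 1 and compound 2 is entangled with the change on the core carbon. The expectation therefore rests on the two aromatic groups being similar in shape, and is a step near the scatter, leaning toward a higher number, a 1.7-fold higher number from compound 1 to compound 4 (0.22 log units; within the scatter). Compound 4 is estimated at 35 nM, expected to fall between 12 nM and 110 nM.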

Compound 4, half-maximal inhibitory concentration: 11 nM
For compound 4 the middle estimate is 3.2-fold (0.50 log units) above the measured one, and the stated range ends above it.
By their numbers in this assay, from the lowest: compounds 4 and 1 (each within the scatter of the next); then compound 2. At a limit, above all of these: compound 3.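

In this assay, replacing the group gives a 1.9-fold lower number from compound 1 to compound 4 (0.28 log units; within the scatter) and so does not separate 5-chlorothiophen-2-yl from 4-chlorophenyl on a saturated chain carbon bound to an oxygen on an aromatic ring. Among the compounds shown here, this is the first readable step at this position, since the only earlier step concerned the group on the aromatic carbon of the core, and it shows that a five-membered aromatic ring with 1 hetero atom can stand in for a six-membered aromatic ring of carbon only without a shift beyond the scatter, even with one heavy atom fewer and one hydrogen-bond acceptor added. Nothing measured in the data shown speaks to why the two groups read alike.

Still open, as far as these compounds go, is the part played by the chlorine on either ring: an unsubstituted thiophene, or a methoxy group or nitrile in place of the chlorine, would test whether this tolerance extends beyond the chlorinated pair. Also open, from the compounds shown here alone, is whether 5-chlorothiophen-2-yl reads the same on the cyclobutyl core of compound 2, and how the gap between compound 1 and compound 2 divides between their two points of difference.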